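The source may hold more compounds than are shown below. What is called first, only, known or untested is meant among the compounds shown, and "the series" means these compounds.

Measured so far in an ADME assay on microsomes from liver (Mus musculus) for pharmacokinetics; a lower number here means slower removal, a higher number faster removal of the compound:
compound 1 `Cc1ccc(S(=O)(=O)N[C@@H](CC(=O)NC(C)(C)C)C(=O)NCCNC(=O)c2ccccc2)cc1` gives 64 mL.min-1.g-1
compound 2 `Cc1ccc(S(=O)(=O)N[C@@H](CC(=O)NC(C)(C)C)C(=O)NCCNC(=O)c2ccccc2F)cc1` gives 141 mL.min-1.g-1

Among the compounds with values here, compound 2 stands at the higher of the two numbers in this assay; the one measured step, a 2.2-fold higher number from compound 1 to compound 2 (0.34 log units; beyond the scatter), separates it from compound 1 and is beyond the scatter, though modest in size.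

The next compound to consider is compound 3 `C#Cc1cccc(C(=O)NCCNC(=O)[C@H](CC(=O)NC(C)(C)C)NS(=O)(=O)c2ccc(C)cc2)c1`. Relative to compound 2 the change is 3-ethynylphenyl in place of 2-fluorophenyl on a carbonyl carbon. Within the data shown here, the single measured step, a 2.2-fold higher number from compound 1 to compound 2 (0.34 log units; beyond the scatter), concerns fluoro replacing hydrogen on that same aromatic ring, so it speaks only indirectly to the present change, in which the fluorine leaves and an ethynyl group enters at a different ring position. Among the measured compounds shown here, no measured pair shows an ethynylphenyl group in this assay. For the measured compounds named here, the step is therefore expected to be small, and given only one precedent the direction is uncertain; a number somewhere between those of compound 1 and compound 2 is the most defensible expectation.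

For compound 3 a value of 115 mL.min-1.g-1 is estimated in this assay, with a range from 55 mL.min-1.g-1 to 250 mL.min-1.g-1. This estimate corresponds to an expected step of a 1.2-fold lower number from compound 2 to compound 3 (0.09 log units; within the scatter).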

Compound 3, intrinsic clearance in microsomes: 97 mL.min-1.g-1
The estimate for compound 3 lay 1.2-fold (0.07 log units) above the measured number; low and high end bracket the measured number.
By their numbers in this assay, from the lowest: compounds 1, 3 and 2 (each within the scatter of the next, the first and the last beyond it).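

In this assay, within the data shown here, the phenyl group on the carbonyl carbon now carries a second kind of substituent: ethynyl in place of hydrogen gives a 1.5-fold higher number from compound 1 to compound 3 (0.18 log units; within the scatter), whereas the one earlier change on this ring, fluoro in place of hydrogen, gave a step beyond the scatter. Exchanging 2-fluorophenyl for 3-ethynylphenyl gives a 1.5-fold lower number from compound 2 to compound 3 (0.16 log units; within the scatter), so compound 3 cannot be told apart from either compound 1 or compound 2, even though those two are separated from each other. Among these compounds, at this place, then, a substituent on the ring does not always move the number beyond the scatter, and the series so far holds one change that does and one that does not. No measurement offered here explains either step.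

The step from compound 2 to compound 3 changes both the substituent and its ring location, so 2-ethynylphenyl or 3-fluorophenyl would be needed to read these two apart. Also open, on these data alone, is how the number responds on this phenyl ring to an amine, a carboxylic acid or a longer alkyne chain in place of ethynyl.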